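The source may hold more compounds than are shown below. What is called first, only, known or untested is meant among the compounds shown, and "the series" means these compounds.

Working notes on the series. Within the data shown here, in a functional assay on CAPAN-1 cells (Homo sapiens) for cytotoxicity (on this read-out lower numbers stand for stronger inhibition and higher numbers for weaker inhibition), compound 3 (`CN1CCN(c2cc3c(cc2F)c(=O)c(-c2nc4s/c(=C\c5ccc(S(N)(=O)=O)cc5)c(=O)n4n2)cn3C2CC2)CC1`) gives 300 nM, the only actual number so far. Compound 1 (`Cc1ccc(/C=c2\sc3nc(-c4cn(C5CC5)c5cc(N6CCN(C)CC6)c(F)cc5c4=O)nn3c2=O)cc1`) reads > 10000 nM, which is a limit and not a number. Compound 2 (`CN1CCN(c2cc3c(cc2F)c(=O)c(-c2nc4s/c(=C\c5ccc(C#N)cc5)c(=O)n4n2)cn3C2CC2)CC1`) reads > 10000 nM, also a limit. That leaves a step that the two limits leave unreadable from compound 1 to compound 2, and the limit of > 10000 nM in this assay, at which 2 of the 3 values shown sit, applies to both compounds.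

Compound 4 (`CN1CCN(c2cc3c(cc2F)c(=O)c(-c2nc4s/c(=C\c5ccc(Cl)cc5)c(=O)n4n2)cn3C2CC2)CC1`) differs from compound 3 by chloro in place of sulfamoyl on an aromatic carbon, para to a large group. Among the measured compounds shown here, two measured steps bear on this, an at least 33-fold lower number from compound 1 to compound 3 (1.52 log units; beyond the scatter) and an at least 33-fold lower number from compound 2 to compound 3 (1.52 log units; beyond the scatter). Both install sulfamoyl and both are large, so removing it is expected to give a large step towards a higher number in this assay. As far as these compounds go, neither methyl nor cyano gave a number in this assay, and chloro itself is untested, so a result reported only as a limit is quite possible. The estimated step is a 23-fold higher number from compound 3 to compound 4 (1.37 log units; beyond the scatter). For compound 4 the expected value is 7000 nM, with an estimated range of 2000 nM to 20000 nM.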

Compound 4, half-maximal inhibitory concentration: > 10000 nM
Compound 4 was reported as a limit; the forecaster's own chance of this, stated with the estimate: 60%; middle value at least 1.4-fold (0.15 log units) from the limit.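

In this assay, chloro in place of sulfamoyl gives an at least 33-fold higher number from compound 3 to compound 4 (1.52 log units; beyond the scatter), so this is the third group at this position, after methyl and cyano, that fails to keep the number reached with sulfamoyl. Among these compounds, compound 3 remains the only compound with an actual number, which ties the effect more closely to sulfamoyl and makes it less likely to be a peculiarity of methyl or cyano. The steps among compound 1, compound 2 and compound 4 cannot be read, and all three compounds stand at one limit: the limit of > 10000 nM in this assay, at which 3 of the 4 values shown sit.

The compounds shown leave open how far apart those three compounds lie. They also leave open whether the sulfamoyl group itself is needed, or whether a methylsulfonyl group, a carboxylic acid or an amine on the same carbon would also give a number.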